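The source may hold more compounds than are shown below. What is called first, only, known or untested is meant among the compounds shown, and "the series" means these compounds.

In a functional assay on HepG2 cells (Homo sapiens) for antiproliferative activity, read by MTT assay, with a stated time of 48 h (a higher number here means a weaker inhibitor, a lower number a stronger inhibitor), compound 1 (`COc1ccc(C2OC(c3ccc4ccccc4c3)=NN2C(C)=O)cc1`) gives 3.6 ug/mL and compound 2 (`CC(=O)N1N=C(c2ccc3ccccc3c2)OC1c1cccc(F)c1`) gives 1.86 ug/mL within the scatter of compound 1, while compound 3 (`CC(=O)N1N=C(c2ccc3ccccc3c2)OC1c1ccc2ccccc2c1`) gives 0.85 ug/mL and lies lower, beyond the scatter of compound 2. Compound 4 (`CC(=O)N1N=C(c2ccc3ccccc3c2)OC1c1ccc(C)cc1`) has 4-methylphenyl in place of 3-fluorophenyl on a saturated ring carbon relative to compound 2. Among the measured compounds shown here, the one measured step at that carbon (a 1.9-fold lower number from compound 1 to compound 2 (0.29 log units; within the scatter)) stays small, so no step beyond the scatter is expected in this assay for this change. The estimated step (a 1.3-fold higher number from compound 2 to compound 4 (0.11 log units; within the scatter)) rests on that single comparison. Compound 4 is estimated at 2.4 ug/mL with an expected range from 1 ug/mL to 5.5 ug/mL in this read-out.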

Compound 4, half-maximal inhibitory concentration: 2.26 ug/mL
Compound 4: the middle estimate sits 1.1-fold (0.03 log units) above what was measured, and the stated range covers the measured number.
By their numbers in this assay, from the lowest: compound 3; then compounds 2, 4 and 1 (each within the scatter of the next).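

In this assay, the 4-methylphenyl group on the saturated ring carbon reads level with both 3-fluorophenyl (a 1.2-fold higher number from compound 2 to compound 4 (0.08 log units; within the scatter)) and 4-methoxyphenyl, where methyl replaces methoxy on an aromatic carbon (a 1.6-fold lower number from compound 1 to compound 4 (0.20 log units; within the scatter)). Methyl, fluoro and methoxy phenyl groups at this position are therefore not separated by any step beyond the scatter. No measurement given here accounts for these small steps. On these data alone, whether an amine or a carboxylic acid on that phenyl ring would give a step beyond the scatter remains open. So does the effect of replacing the acetyl group with a longer acyl chain.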